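This account rests on a few compounds, and the source may have more. Where it says the series, first, only, none or still open, it means among the compounds named here.

Working notes on the series. In an assay on lung parenchyma for displacement of a labelled ligand from cysteinyl leukotriene receptor 1 (Cavia porcellus) (a lower number here means a stronger inhibitor, a higher number a weaker inhibitor), compound 2 `CCCCCC(=O)Nc1ccc2c(c1)c(Cc1ccc(C(=O)O)cc1OC)cn2C` gives 1900 nM, the highest of the two numbers recorded, while compound 1 `CCCn1cc(Cc2ccc(C(=O)O)cc2OC)c2cc(NC(=O)OC3CCCC3)ccc21` gives 58 nM in this assay, and the two differ beyond the scatter. Compound 3 `COc1cc(C(=O)O)ccc1Cc1cn(C)c2ccc(NC(=O)OC3CCCC3)cc12` has not been measured; relative to compound 2 it carries cyclopentyloxy in place of pentyl on a carbonyl carbon. Because compound 1 already bears the cyclopentyloxycarbonylamino group and gives 58 nM, a large step to a lower number is expected, a 19-fold lower number from compound 2 to compound 3 (1.28 log units; beyond the scatter). Compound 3 is estimated at 100 nM in this assay, with a range from 30 nM to 400 nM.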

Compound 3, inhibition constant: 157 nM
For compound 3 the middle estimate is 1.6-fold (0.20 log units) below the measured one; the measured number falls inside the stated range.
By their numbers in this assay, from the lowest: compound 1; then compound 3; then compound 2.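

In this assay, cyclopentyloxy in place of pentyl on a carbonyl carbon gives a 12-fold lower number from compound 2 to compound 3 (1.08 log units; beyond the scatter) and so accounts for much of the gap between the two earlier compounds. The second place also counts, though by less: hydrogen in place of ethyl on a saturated chain carbon bound to an aromatic nitrogen gives a 2.7-fold higher number from compound 1 to compound 3 (0.43 log units; beyond the scatter). No measurement shown explains either step.

The compounds shown do not separate the contribution of the ring from that of the oxygen in cyclopentyloxy, which pentyloxy or cyclopentyl on that carbonyl carbon could address. As far as these compounds go, how a longer chain on the saturated chain carbon would read also remains open.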